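Cytotoxicity notes on compounds 1 to 4

The source may report more compounds than this note shows. Statements on the series, on what has been measured and on what is new or still open speak of the compounds shown alone.

Measured compounds, read out in an ADME assay on BJ cells (Homo sapiens) for cytotoxicity, with a stated time of 72 h; on this read-out higher numbers stand for an effect only at larger amounts of compound and lower numbers for an effect already at smaller amounts:
Compound 1 `Cc1cc(NC(=O)Nc2ccc(C)c(Cl)c2)c2ccccc2n1`: compound 1 gives > 25000 nM, a limit of the assay.
Compound 2 `Cc1cc(NC(=O)Nc2ncccc2C)c2ccccc2n1`: compound 2 gives > 25000 nM, a limit of the assay.
Compound 3 `Cc1cc(NC(=O)Nc2cccc(Cl)c2)c2ccccc2n1`: compound 3 gives > 25000 nM, a limit of the assay.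

Compound 3 stands at the same limit as every other value shown, (the limit of > 25000 nM in this assay, at which 3 of the 3 values shown sit). The two steps leading into compound 3, a step that the two limits leave unreadable from compound 1 to compound 3 and a step that the two limits leave unreadable from compound 2 to compound 3, cannot be sized: both ends of each step sit at that limit. Compound 4 `Cc1cc(NC(=O)Nc2cccc([N+](=O)[O-])c2)c2ccccc2n1` differs from compound 3 by nitro in place of chloro on an aromatic carbon. Neither measured step touches a nitro group, and neither gives a readable size. From them, no direction beyond the scatter is expected for compound 4. Compound 4 is expected at 30000 nM, with a range from 10000 nM to 100000 nM, and most likely to be reported again only as a limit. The step that the limit leaves unreadable from compound 3 to compound 4 is accordingly estimated to stay within the scatter.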

Compound 4, half-maximal effective concentration: > 25000 nM
Compound 4: no number, only a limit; the forecaster's own chance of this, stated with the estimate: 80%; the middle value is on the limit's open side.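

No new step can be read from compound 3 to compound 4, since both values are limits of the assay:  the limit of > 25000 nM in this assay, at which 4 of the 4 values shown sit.

The compounds shown leave open at what concentration, if any, compounds 1 to 4 affect these cells, and whether any single change in the series alters that concentration.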